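Repositioning the Nitro Group on a Shared Ester Core

This account rests on a few compounds, and the source may have more. Where it says the series, first, only, none or still open, it means among the compounds named here.

Measured compounds:
Compound 1 `C/C(=C\CC/C(C)=C/CC[C@@H]1[C@@]2(C)CCC(=O)C(C)(C)[C@H]2CC[C@@]1(C)O)CC/C=C(\C)C(=O)OCc1cn(C[C@@H]2O[C@H](n3ccc(=O)[nH]c3=O)[C@H]3OC(C)(C)O[C@H]32)nn1` — in an ADME assay on L132 cells (Homo sapiens) for cytotoxicity, read by MTT assay, with a stated time of 48 h (on this read-out higher numbers stand for weaker inhibition and lower numbers for stronger inhibition), compound 1 gives only a limit, > 150000 nM.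
Compound 2 `C/C(=C\CC/C(C)=C/CC[C@@H]1[C@@]2(C)CCC(=O)C(C)(C)[C@H]2CC[C@@]1(C)O)CC/C=C(\C)C(=O)OCc1cn(-c2ccc([N+](=O)[O-])cc2)nn1` — in this assay compound 2 gives only a limit, > 150000 nM.
Compound 3 `C/C(=C\CC/C(C)=C/CC[C@@H]1[C@@]2(C)CCC(=O)C(C)(C)[C@H]2CC[C@@]1(C)O)CC/C=C(\C)C(=O)OCc1cn(-c2ccc(Br)cc2)nn1` — in this assay compound 3 gives only a limit, > 150000 nM.

Compound 2 therefore stands at a limit of this assay and not at a number, and the two further values shown are limits as well. Among the measured compounds shown here, the one step between measured compounds that differ in one place, a step that the two limits leave unreadable from compound 2 to compound 3, bromo in place of nitro on an aromatic carbon, is left unreadable by the two limits. Compound 4 `C/C(=C\CC/C(C)=C/CC[C@@H]1[C@@]2(C)CCC(=O)C(C)(C)[C@H]2CC[C@@]1(C)O)CC/C=C(\C)C(=O)OCc1cn(-c2ccccc2[N+](=O)[O-])nn1` differs from compound 2 by 2-nitrophenyl in place of 4-nitrophenyl on an aromatic nitrogen. For the measured compounds named here, no measured step speaks to this change in a readable size; what the numbers show is the limit of > 150000 nM in this assay, at which 3 of the 3 values shown sit. On that basis the step that the limit leaves unreadable from compound 2 to compound 4 is expected to be none that can be read, with compound 4 most likely again at the limit. Compound 4 is estimated at 200000 nM, within 100000 nM to 400000 nM.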

Compound 4, half-maximal inhibitory concentration: > 150000 nM
Compound 4 gave a limit, no number; the forecaster's own chance of this, stated with the estimate: 85%; the middle value does not contradict the limit.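

In this assay compound 4 gives only a limit, > 150000 nM. Among the compounds shown here, no new step to compound 4 can be read from compound 2 or compound 3: the limit of > 150000 nM in this assay, at which 4 of the 4 values shown sit. The compounds shown leave open whether 2-nitrophenyl, 4-nitrophenyl and 4-bromophenyl differ at all in this assay.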